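This account rests on a few compounds, and the source may have more. Where it says the series, first, only, none or still open, it means among the compounds named here.

Measured so far:
- compound 1 `COc1cc(-c2cc(/C=C/C(=O)c3ccc(N)cc3)[nH]n2)cc(OC)c1OC` gives -5%
- compound 2 `COc1ccc(-c2cc(/C=C/C(=O)c3ccc(OC)c(OC)c3)[nH]n2)cc1` gives -10%
- compound 3 `COc1cc(-c2cc(/C=C/C(=O)c3ccc(Cl)c(Cl)c3)[nH]n2)cc(OC)c1OC` gives 24%

These three share one core and were tested in a functional assay on MOLT-4 cells (Homo sapiens) for cytotoxicity, read by sulforhodamine B assay, with a stated time of 48 h, tested at 10 uM; on this read-out higher numbers stand for a weaker effect at the one concentration tested and lower numbers for a stronger effect. Compound 1 stands close to compound 2, the two values lying within the usual scatter, so no order can be read between them. Within the data shown here, compound 3 is the one that differs clearly: the only single-point step among the measured compounds, a number 29 percentage points higher from compound 1 to compound 3 (beyond the scatter), exchanges the group on the carbonyl carbon.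

Compound 4 `COc1ccc(-c2cc(/C=C/C(=O)c3ccc(N)cc3)[nH]n2)cc1OC` is not yet measured. It differs from compound 1 by hydrogen in place of methoxy on an aromatic carbon.

Among the measured compounds shown here, no measured step touches this ring or removes a methoxy group, so the one step available, on the carbonyl carbon, does not bear on the change in hand. The two compounds that keep the same group on the carbonyl carbon as compound 4, compound 1 and compound 2, differ in several places at once and give values within the scatter of each other. Nothing in these data therefore points to a shift beyond the scatter, and the expected step of a number 2 percentage points higher from compound 1 to compound 4 (within the scatter) is small. Compound 4 is expected to give about -3% in this assay, with a likely range from -20% to 15%.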

Compound 4, a percentage reported as activity, at one concentration (the size of the read-out at that concentration, not a potency): 6%
For compound 4 the middle estimate is 9 percentage points below the measured one; the range from low to high includes it.
By their numbers in this assay, from the lowest: compounds 2 and 1 (each within the scatter of the next); then compound 4; then compound 3.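

In this assay the exchange of methoxy for hydrogen, on the aromatic carbon that is ortho to a methoxy group and meta to a large group, comes with a number 11 percentage points higher from compound 1 to compound 4 (beyond the scatter) and so a weaker effect at the one concentration tested. Among these compounds, this is the first single-place change on this ring, since the only earlier step concerned the group on the carbonyl carbon, and it shows that this methoxy group cannot be lost without a measurable shift in the read-out. No measurement shown explains why the number moves in this direction.

Still open, going by these compounds, is whether the effect depends on the methoxy group itself or would hold with another group at this position, such as hydroxy, ethoxy or a fluorine atom. Also open, on these data alone, is whether the same exchange would shift the number in a similar way in a compound with 3,4-dichlorophenyl on the carbonyl carbon, since this step has been read only with 4-aminophenyl there.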